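The source may report more compounds than this note shows. Statements on the series, on what has been measured and on what is new or still open speak of the compounds shown alone.

Measured in an ADME assay for permeability, using PAMPA, with a stated time of 4 h, at pH 7.4; a higher number here means that the compound crosses the layer faster, a lower number that the compound crosses the layer more slowly:
- compound 1 `NCCCCN(C[C@H]1Cc2cccnc2CN1)[C@H]1CCCc2cccnc21`: 6 nm/s
- compound 2 `NCCCCN(C[C@H]1Cc2nccnc2CN1)[C@H]1CCCc2cccnc21`: 2 nm/s
- compound 3 `NC/C=C\CN(C[C@H]1Cc2ncccc2CN1)[C@H]1CCCc2cccnc21`: 68 nm/s

Compound 3 has the highest of the three values in this assay, and compounds 1 and 2 both lie lower, beyond the scatter. Among the compounds with values here, no measured pair differs in one place only, so no direct step is available to guide the next comparison.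

Compound 4 `CN(C)CCCCN(C[C@H]1Cc2ncccc2CN1)[C@H]1CCCc2cccnc21` carries 3-(dimethylamino)propyl in place of 3-aminoprop-1-en-1-yl on a saturated chain carbon bound to an amine nitrogen. Compound 1 at 6 nm/s and compound 2 at 2 nm/s also lack the chain double bond, but their cores differ from that of compound 3, so they are only a weak pointer downward. A modest fall in this assay is expected, possibly not clearing the scatter. The expected change is a 1.9-fold lower number from compound 3 to compound 4 (0.29 log units; within the scatter). For compound 4 the estimated value is 35 nm/s, with an expected range of 8 nm/s to 130 nm/s.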

Compound 4, apparent permeability: 240 nm/s
Estimate against measurement, compound 4: 6.9-fold (0.84 log units) below, outside the stated range (above it).
By their numbers in this assay, from the lowest: compound 2; then compound 1; then compound 3; then compound 4.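

Within the data shown here, on a saturated chain carbon bound to an amine nitrogen, 3-(dimethylamino)propyl in place of 3-aminoprop-1-en-1-yl gives a 3.5-fold higher number from compound 3 to compound 4 (0.55 log units; beyond the scatter) in this assay, the only direct step so far. The position therefore responds to the chain and its end group, and the response here is upward and beyond the scatter. The change removes the chain double bond and the hydrogen-bond donor and adds heavy atoms in a single step, so the result cannot be assigned to any one of these. No measurement shown bears on the reason for the step.

Open, from the compounds shown here alone, is how the step divides between the chain and its end group: a 4-aminobutyl or 4-(methylamino)butyl chain on the same core would separate the two. Going by these compounds, whether a longer chain carrying the dimethylamino group holds the value of compound 4 at 240 nm/s also remains open.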